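Benzyl in Place of Trifluoromethyl: Forecast for Compound 4

The source may hold more compounds than are shown below. What is called first, only, known or untested is meant among the compounds shown, and "the series" means these compounds.

Three compounds share one core and differ only in the group on the anilide ring. Compound 1 `C[C@H](NC(=O)C(=O)Nc1ccccc1)C(=O)N[C@@H](CC(=O)O)C(=O)COc1c(F)c(F)cc(F)c1F` carries hydrogen there and in a functional assay on THP-1 cells (Homo sapiens) for inhibition (a higher number here means a weaker inhibitor, a lower number a stronger inhibitor), compound 1 gives 140 nM. Compound 2 `C[C@H](NC(=O)C(=O)Nc1ccccc1Br)C(=O)N[C@@H](CC(=O)O)C(=O)COc1c(F)c(F)cc(F)c1F` carries bromo and in this assay compound 2 gives 50 nM. Compound 3 `C[C@H](NC(=O)C(=O)Nc1ccccc1C(F)(F)F)C(=O)N[C@@H](CC(=O)O)C(=O)COc1c(F)c(F)cc(F)c1F` carries trifluoromethyl and in this assay compound 3 gives 190 nM, the highest of the three numbers: its gap to compound 1 is within the scatter, while a 3.8-fold higher number from compound 2 to compound 3 (0.58 log units; beyond the scatter) lies beyond it. Compound 4 `C[C@H](NC(=O)C(=O)Nc1ccccc1Cc1ccccc1)C(=O)N[C@@H](CC(=O)O)C(=O)COc1c(F)c(F)cc(F)c1F` changes the same position: benzyl in place of trifluoromethyl on an aromatic carbon. Going by the values given here, the steps that bear on this are a 1.4-fold higher number from compound 1 to compound 3 (0.13 log units; within the scatter) and a 2.8-fold lower number from compound 1 to compound 2 (0.45 log units; beyond the scatter), both small, so substituents at this position have so far moved the number only modestly. Among the compounds with values here, no measured step involves benzyl, so the expectation stays close to compound 3. Compound 4 is therefore expected to give 150 nM, with a range from 50 nM to 450 nM. That estimate corresponds to an expected step of a 1.3-fold lower number from compound 3 to compound 4 (0.10 log units; within the scatter).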

Compound 4, half-maximal inhibitory concentration: 540 nM
Estimate against measurement, compound 4: 3.6-fold (0.56 log units) below; the measured number lies above the stated range.
By their numbers in this assay, from the lowest: compound 2; then compounds 1 and 3 (each within the scatter of the next); then compound 4.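

In this assay, going by these compounds alone, benzyl is the first group at this position to separate from hydrogen on the weaker side, giving a 3.9-fold higher number from compound 1 to compound 4 (0.59 log units; beyond the scatter) where trifluoromethyl stayed within the scatter of hydrogen. The same group gives a 2.8-fold higher number from compound 3 to compound 4 (0.45 log units; beyond the scatter) against trifluoromethyl and an 11-fold higher number from compound 2 to compound 4 (1.03 log units; beyond the scatter) against bromo, and that last step is the only large one in the set. The position therefore moves the number in both directions from hydrogen, lower with bromo and higher with benzyl, and spans a wider range than the three earlier compounds showed.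

Nothing measured alongside these compounds accounts for the rise with benzyl. Going by these compounds, it remains open whether a phenyl group without the connecting carbon, an amine or a longer chain ending in a carboxylic acid would fall nearer bromo or benzyl.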